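Rearranging a Methylpyridine on a Sulfonyl Sulfur

The source may hold more compounds than are shown below. What is called first, only, known or untested is meant among the compounds shown, and "the series" means these compounds.

Compound 1 `CNCc1cc(-c2cccnc2F)n(S(=O)(=O)c2cccnc2)c1`: 35 ng.h/mL
Compound 2 `CNCc1cn(S(=O)(=O)c2ncccc2C)c(-c2cccnc2F)c1F`: "not determined" (no result reported)

In an ADME assay on the whole organism (plasma, Rattus norvegicus, strain Sprague-Dawley) for pharmacokinetics, read by LC-MS, using cassette dosing, at a dose of 0.2 mg/kg by the intravenous route (a higher number here means more compound in the circulation at the dose given, a lower number less compound in the circulation), compound 1 gives 35 ng.h/mL. For compound 2 this assay reports "not determined" (no result reported), so compound 2 has no single number to stand on. Compound 3 `CNCc1cn(S(=O)(=O)c2ccc(C)nc2)c(-c2cccnc2F)c1F` has the same atoms as compound 2, joined differently: 6-methylpyridin-3-yl in place of 3-methylpyridin-2-yl on a sulfonyl sulfur. For the measured compounds named here, no measured pair shows what this rearrangement does in this assay, so no direction beyond the scatter can be expected. Going by the values given here, the only number at hand belongs to compound 1 at 35 ng.h/mL, which differs from compound 3 in several places. Compound 3 is therefore estimated near 35 ng.h/mL, within a wide range from 8 ng.h/mL to 150 ng.h/mL.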

Compound 3, area under the concentration-time curve: 41 ng.h/mL
Estimate against measurement, compound 3: 1.2-fold (0.07 log units) below; measured number inside the range.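

For the compounds shown here, compound 2 has no single number, and no step to compound 3 can be read from it. No evidence at hand bears on this result. Going by these compounds, what swapping 3-methylpyridin-2-yl for 6-methylpyridin-3-yl on a sulfonyl sulfur does in this assay stays open.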